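Methoxy for pyrazolyl on the chloro-bearing core

A few compounds are considered here, and "the series" means these few. Any claim that something is new, unique, unknown or untested is made for them only; others in the source may bear on it.

Compound 3 `Clc1ccc2c(c1-c1ccn[nH]1)CCC2c1ncc[nH]1` gives in a functional assay on CHO cells for agonist activity at Alpha-1A adrenergic receptor (Homo sapiens), read by FLIPR and calcium flux (a lower number here means a smaller maximal response, a higher number a larger maximal response), 40%. Compound 1 `COc1c(C)ccc2c1CCC2c1ncc[nH]1` stands level with it at 40%, the two together the lowest of the three numbers, while compound 2 `COc1cccc2c1CCC2c1ncc[nH]1` reaches 65%. For the measured compounds named here, the one measured step, a number 25 percentage points higher from compound 1 to compound 2 (beyond the scatter), covers hydrogen in place of methyl on an aromatic carbon and touches a different place on the core.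

Compound 4 `COc1c(Cl)ccc2c1CCC2c1ncc[nH]1` differs from compound 3 by methoxy in place of 1H-pyrazol-5-yl on an aromatic carbon. Going by the values given here, no measured pair shows this exchange directly, so the size of the step is uncertain. Compound 4 does keep a chloro group ortho to the methoxy and otherwise matches compound 1, whose number 40% is level with compound 3; compound 2, which lacks a substituent there, is the only one that goes higher. Compound 4 is therefore expected to show no step beyond the scatter from compound 3, a number 5 percentage points higher from compound 3 to compound 4 (within the scatter). The estimate for compound 4 in this assay is 45%, with a range from 25% to 70%.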

Compound 4, largest response reached (Emax), in percent of the reference or control that the assay uses: 24%
For compound 4 the middle estimate is 21 percentage points above the measured one, outside the stated range (below it).
By their numbers in this assay, from the lowest: compound 4; then compounds 1 and 3 (each within the scatter of the next); then compound 2.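

In this assay the aromatic carbon that bears the chloro group in compound 4 now has three groups compared on the same methoxy core, where only hydrogen and methyl could be compared before. Chloro in place of hydrogen gives a number 41 percentage points lower from compound 2 to compound 4 (beyond the scatter) and chloro in place of methyl gives a number 16 percentage points lower from compound 1 to compound 4 (beyond the scatter), so with methoxy held fixed, the maximal response falls from hydrogen through methyl to chloro. With the chloro group held fixed, methoxy in place of 1H-pyrazol-5-yl gives a number 16 percentage points lower from compound 3 to compound 4 (beyond the scatter), so the two groups are now separated on the chloro-bearing core, and no measurement shown accounts for either change.

As far as these compounds go, it remains open whether the order of hydrogen, methyl and chloro also holds with 1H-pyrazol-5-yl in place of methoxy. An amine or a carboxylic acid on that same aromatic carbon would show how far the response follows the group there.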